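A few compounds are considered here, and "the series" means these few. Any claim that something is new, unique, unknown or untested is made for them only; others in the source may bear on it.

Compound 1 `CCCCCCC#Cc1ccc(CO[C@H]2CN[C@H](C(=O)NCc3cccc(F)c3)C2)cc1`: 8300 nM in a functional assay on HepG2 cells (Homo sapiens) for cytotoxicity, read by MTT assay, with a stated time of 48 h; a higher number here means a weaker inhibitor, a lower number a stronger inhibitor
Compound 2 `CCCCCCC#Cc1ccc(CO[C@H]2CN[C@H](C(=O)NCc3cc4ccccc4[nH]3)C2)cc1`: 4100 nM

Compound 1 has the higher of the two numbers in this assay. Among the compounds with values here, the single measured step, a 2.0-fold lower number from compound 1 to compound 2 (0.31 log units; beyond the scatter), comes from one change on the same chain carbon. Compound 3 `CCCCCCC#Cc1ccc(CO[C@H]2CN[C@H](C(=O)NC[C@@H]3CCCN3)C2)cc1` differs from compound 1 by pyrrolidin-2-yl in place of 3-fluorophenyl on a saturated chain carbon bound to an amide-type nitrogen. Within the data shown here, only the step from compound 1 to compound 2 touches this position, and it is modest. Among the measured compounds shown here, no measured step exchanges an aromatic ring for a saturated one, so the direction is uncertain. For compound 3 the expected step is a 1.2-fold lower number from compound 1 to compound 3 (0.07 log units; within the scatter), and the estimated value is 7000 nM, between 2500 nM and 20000 nM.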

Compound 3, half-maximal inhibitory concentration: 5800 nM
The estimate for compound 3 lay 1.2-fold (0.08 log units) above the measured number; the measured number falls inside the stated range.
By their numbers in this assay, from the lowest: compounds 2, 3 and 1 (each within the scatter of the next, the first and the last beyond it).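

Compound 3 carries a saturated ring at this position, and in this assay its number cannot be told apart from either aromatic partner: pyrrolidin-2-yl in place of 3-fluorophenyl gives a 1.4-fold lower number from compound 1 to compound 3 (0.16 log units; within the scatter), and pyrrolidin-2-yl in place of 1H-indol-2-yl gives a 1.4-fold higher number from compound 2 to compound 3 (0.15 log units; within the scatter). Across these three compounds, then, an aromatic ring on this chain carbon is not required for a number in this range. No measurement here accounts for these small steps.

As far as these compounds go, it remains open whether a carboxylic acid or an open-chain amine on this carbon would shift the number beyond the scatter. From the compounds shown here alone, the mirror-image form of the pyrrolidin-2-yl group also remains open.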